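Solubility notes on the shared core with varied aryl groups

The compounds below may be only part of what the source reports. "The series", "measured", "known", "first", "only" and "open" are said of these compounds alone.

Measured compounds:
compound 1 `CNc1nc(NCCCN(C)C)c2sc(-c3ccc(C(F)(F)F)cc3)cc2n1`: 177 ug/mL
compound 2 `CNc1nc(NCCCN(C)C)c2sc(-c3cccc(C(F)(F)F)c3)cc2n1`: 160 ug/mL
compound 3 `CNc1nc(NCCCN(C)C)c2sc(-c3cncnc3)cc2n1`: 194 ug/mL

In a physicochemical assay for solubility, read by HPLC, in phosphate buffer, at pH 6.5 (on this read-out lower numbers stand for lower solubility and higher numbers for higher solubility), compound 3 gives 194 ug/mL, the top of a narrow cluster; compound 1 at 177 ug/mL and compound 2 at 160 ug/mL both lie within the scatter of it, so no order among the three can be read. Compound 4 `CNc1nc(NCCCN(C)C)c2sc(-c3ccoc3)cc2n1` is not yet measured. It differs from compound 3 by furan-3-yl in place of pyrimidin-5-yl on an aromatic carbon. For the measured compounds named here, no step between measured compounds is available to anchor this change, so the expectation rests on the flat spread of compounds 1 to 3. The step is estimated as a 1.5-fold lower number from compound 3 to compound 4 (0.17 log units; within the scatter), a small drop, not expected to go beyond the scatter. Compound 4 is estimated at 130 ug/mL, with a range from 60 ug/mL to 260 ug/mL.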

Compound 4, solubility: 203 ug/mL
The estimate for compound 4 lay 1.6-fold (0.19 log units) below the measured number; low and high end bracket the measured number.
By their numbers in this assay, from the lowest: compounds 2, 1, 3 and 4 (each within the scatter of the next).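

Swapping in furan-3-yl for pyrimidin-5-yl on this aromatic carbon, next to the ring sulfur, gives the first single-place step at this position in this assay, with a 1.0-fold higher number from compound 3 to compound 4 (0.02 log units; within the scatter) as the result. A six-membered aromatic ring with 2 hetero atoms and a five-membered aromatic ring with 1 hetero atom are therefore not separated by this read-out. No available evidence bears on this result.

As far as these compounds go, it remains open whether an amine or a carboxylic acid on this aromatic carbon would give a step beyond the scatter in this assay. From the compounds shown here alone, the effect of a longer chain in place of the dimethylaminopropyl side chain also remains open.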